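Swapping pyrrolidin-1-yl for propylamino on a thiocarbonyl carbon

The compounds below may be only part of what the source reports. "The series", "measured", "known", "first", "only" and "open" are said of these compounds alone.

Measured in a functional assay on K562 cells (Homo sapiens) for cytotoxicity, read by MTT assay, with a stated time of 72 h; a higher number here means a weaker inhibitor, a lower number a stronger inhibitor:
- Compound 1 `CC(C)(C)NC(=S)N/N=C1\CC(c2ccc(O)cc2)Oc2cc(O)ccc21`: 8900 nM
- Compound 2 `Oc1ccc(C2C/C(=N\NC(=S)N3CCCC3)c3ccc(O)cc3O2)cc1`: 17300 nM

Only these two compounds have been measured, and compound 2 at 17300 nM stands within the scatter of compound 1. Compound 3 `CCCNC(=S)N/N=C1\CC(c2ccc(O)cc2)Oc2cc(O)ccc21` has not yet been measured. It differs from compound 2 at one place, on a thiocarbonyl carbon, with propylamino in place of pyrrolidin-1-yl on a thiocarbonyl carbon. Among the measured compounds shown here, the single measured step that bears on this change involves pyrrolidin-1-yl at the same place, with (tert-butyl)amino as the group it replaces: a 1.9-fold higher number from compound 1 to compound 2 (0.29 log units; within the scatter). On that evidence, no step beyond the scatter is expected for compound 3 in this assay, although one step is thin support. The expected step is a 1.4-fold lower number from compound 2 to compound 3 (0.16 log units; within the scatter). For compound 3 the expected value is 12000 nM, with an estimated range from 5000 nM to 28000 nM.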

Compound 3, half-maximal inhibitory concentration: 31000 nM
For compound 3 the middle estimate is 2.6-fold (0.41 log units) below the measured one, outside the stated range (above it).
By their numbers in this assay, from the lowest: compounds 1, 2 and 3 (each within the scatter of the next, the first and the last beyond it).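

In this assay, replacing pyrrolidin-1-yl with propylamino on the thiocarbonyl carbon gives a step within the scatter (a 1.8-fold higher number from compound 2 to compound 3 (0.25 log units; within the scatter)), so this assay does not separate the ring from the open chain. Among the compounds shown here, the position nevertheless proves responsive: propyl in place of tert-butyl on the amide-type nitrogen gives the only step beyond the scatter (a 3.5-fold higher number from compound 1 to compound 3 (0.54 log units; beyond the scatter)), while compound 2 lies within the scatter of both compound 1 and compound 3. Nothing available accounts for this difference.

The three compounds leave open how a methylamino, a longer butylamino or an isopropylamino group would read at this place. They also leave open whether a piperidin-1-yl ring or a morpholin-4-yl ring would fall with pyrrolidin-1-yl.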